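This account rests on a few compounds, and the source may have more. Where it says the series, first, only, none or still open, it means among the compounds named here.

Measured compounds:
- compound 1, `C[C@H](Nc1nc(N)nc(N)c1C#N)c1cc2ccc(F)cn2c(=O)c1-c1ccccc1`: 42%
- compound 2, `C[C@H](Nc1nc(N)ncc1C#N)c1cc2ccc(F)cn2c(=O)c1-c1ccccc1`: 11%
- compound 3, `C[C@H](Nc1nc(N)nc(N)c1C#N)c1cc(=O)n2cc(F)ccc2c1-c1ccccc1`: "not determined" (no result reported)

The study concerns three measured compounds and one still to be measured. In an ADME assay on microsomes from liver (Mus musculus), read by LC-MS, using NADPH, with a stated time of 30 min, tested at 1 uM (on this read-out lower numbers stand for a less stable compound and higher numbers for a more stable compound), compound 1 gives 42%. Compound 2 differs from compound 1 by hydrogen in place of amino on an aromatic carbon, and in this assay compound 2 gives 11%, which amounts to a number 31 percentage points lower from compound 1 to compound 2 (beyond the scatter). Compound 3 carries the same pyrimidinyl group as compound 1 on a core that has the same atoms joined differently; the difference between the two cores is not broken down here. For compound 3 this assay reports no number.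

Compound 4, `C[C@H](Nc1ncnc(N)c1C#N)c1cc(=O)n2cc(F)ccc2c1-c1ccccc1`, stands to compound 3 as compound 2 stands to compound 1, in that both are hydrogen in place of amino on an aromatic carbon, yet the surroundings differ: from compound 3 to compound 4 the change is hydrogen in place of amino on an aromatic carbon, whereas in the earlier pair the amino sat next to the ring nitrogen, ortho to a cyano group and opposite the ring nitrogen. It is therefore the same kind of change, not the same change. With no value for compound 3, the expectation for compound 4 rests on compound 1 alone and on the size of the earlier step. A drop of a comparable kind is expected because a number 31 percentage points lower from compound 1 to compound 2 (beyond the scatter), though the different place leaves its size uncertain. Compound 4 is expected to give about 20% in this assay, plausibly between 5% and 45%.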

Compound 4, percent of the compound remaining: 69%
Compound 4: middle estimate off by 49 percentage points, on the low side; the measured number lies above the stated range.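

In this assay, among these compounds, compound 3 stands as "not determined" (no result reported) and compound 4 gives 69% and so no step between these two compounds can be read. The compounds shown leave open whether going from 2,6-diamino-5-cyanopyrimidin-4-yl to 6-amino-5-cyanopyrimidin-4-yl on this core moves the number the same way as the step of a number 31 percentage points lower from compound 1 to compound 2 (beyond the scatter) on the other core. Nothing given here bears on the result for compound 4.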